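A few compounds are considered here, and "the series" means these few. Any claim that something is new, unique, unknown or untested is made for them only; others in the source may bear on it.

In a functional assay on OVCAR-8 cells (Homo sapiens) for antiproliferative activity, read by sulforhodamine B assay, with a stated time of 48 h (a higher number here means a weaker inhibitor of growth, a lower number a stronger inhibitor of growth), compound 1 `O=C(NCCCNc1cc(-c2cn(-c3ccccc3)nc2-c2cccc(O)c2)ccn1)Nc1ccc(F)cc1` gives 9260 nM and compound 2 `O=C(NCCCNc1cc(-c2cn(-c3ccccc3)nc2-c2cccc(O)c2)ccn1)Nc1cccc(C(F)(F)F)c1` gives 10000 nM, so the two stand level within the scatter. Compound 3 `COc1cccc(-c2nn(-c3ccccc3)cc2-c2ccnc(NCCCNC(=O)Nc3ccc(F)cc3)c2)c1` differs from compound 1 at one place: methyl in place of hydrogen on an oxygen on an aromatic ring, that is, 3-hydroxyphenyl to 3-methoxyphenyl. For the measured compounds named here, the only measured step, a 1.1-fold higher number from compound 1 to compound 2 (0.03 log units; within the scatter), concerns an amide-type nitrogen, so it bears only indirectly on this change. Going by the values given here, no measured step touches the oxygen. The estimated step is a 1.0-fold higher number from compound 1 to compound 3 (0.01 log units; within the scatter), which is no change beyond the scatter in this assay. For compound 3 the expected value is 9500 nM, with an estimated range of 4500 nM to 20000 nM.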

Compound 3, concentration for total growth inhibition: > 37000 nM
Compound 3: a limit, no number; the forecaster's own chance of this, stated with the estimate: 20%; middle value at least 3.8-fold (0.59 log units) from the limit.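

At this oxygen on an aromatic ring, methyl in place of hydrogen is the only change shown that moves the number beyond the scatter in this assay: an at least 3.9-fold higher number from compound 1 to compound 3 (0.60 log units; beyond the scatter). The hydroxy of compound 1 therefore matters to growth inhibition here, whereas the change on the amide-type nitrogen did not register. Compound 3 has a limit of the assay and not a number, so the full size of this step stays unknown: the limit of > 37000 nM in this assay, at which 1 of the 3 values shown sits.

The compounds shown do not tell how an amine or a carboxylic acid in place of the hydroxy would read. As far as these compounds go, whether an ethyl on this oxygen would behave as the methyl does also stays open.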